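The compounds below may be only part of what the source reports. "The series", "measured", "known", "first", "only" and "open" are said of these compounds alone.

Working notes on the series. Two compounds have numbers in a functional assay on T-24 cells (Homo sapiens) for cytotoxicity, read by neutral red uptake, with a stated time of 72 h; a lower number here means a stronger inhibitor, a higher number a weaker inhibitor: compound 1 `CCCCCCNc1nc(SCC)nc2ncccc12` gives 5900 nM, and compound 2 `CCCCNc1nc(SC(C)C)nc2ncccc12` gives 12300 nM, the higher of the two numbers, the gap between them lying beyond the usual scatter. Compound 3 `CCCCCCNc1nc(SC(C)C)nc2ncccc12` is not yet measured in this assay. It differs from compound 2 by ethyl in place of hydrogen on a saturated chain carbon, four bonds along the chain from a nitrogen on an aromatic ring. The step from compound 2 to compound 3 is expected to lower the number by about a 1.8-fold lower number from compound 2 to compound 3 (0.24 log units; within the scatter), since compound 1, which also carries the longer chain, gives 5900 nM. For compound 3 the estimate in this assay is 7000 nM, within 3000 nM to 16000 nM.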

Compound 3, half-maximal inhibitory concentration: 15800 nM
For compound 3 the middle estimate is 2.3-fold (0.35 log units) below the measured one; the measured number falls inside the stated range.
By their numbers in this assay, from the lowest: compound 1; then compounds 2 and 3 (each within the scatter of the next).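

In this assay, ethyl in place of hydrogen at this chain position gives a 1.3-fold higher number from compound 2 to compound 3 (0.11 log units; within the scatter), so lengthening the chain on the nitrogen shows no readable effect when isopropyl sits on the sulfur. Methyl in place of hydrogen on a saturated chain carbon bound to a saturated chain carbon and a sulfur gives a 2.7-fold higher number from compound 1 to compound 3 (0.43 log units; beyond the scatter), the one new step beyond the scatter. No measured evidence bears on the reason for either step. Going by these compounds, how a longer chain or a benzyl group on the sulfur would read in this assay remains open.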